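Removing the methoxy from the core of compound 1

The source may hold more compounds than are shown below. What is called first, only, known or untested is meant among the compounds shown, and "the series" means these compounds.

Measured so far:
compound 1 `COc1ccc2cc(-c3cc3=O)ccc2c1`: 1990 nM
compound 2 `O=c1cc1-c1ccc(Oc2ccccc2)cc1`: 730 nM

In an assay on isolated protein for inhibition of glutathione S-transferase P (Homo sapiens) (a higher number here means a weaker inhibitor, a lower number a stronger inhibitor), compound 1 gives 1990 nM, the highest of the two numbers. Compound 2 gives 730 nM, a gap beyond the scatter. Compound 3 `O=c1cc1-c1ccc2ccccc2c1` is not yet measured; it differs from compound 1 by hydrogen in place of methoxy on an aromatic carbon. Among the measured compounds shown here, no measured pair covers this change, so only a small step is expected, with no clear direction beyond the scatter. For compound 3 the expected value is 2500 nM, in the range 800 nM to 8000 nM. The step of a 1.3-fold higher number from compound 1 to compound 3 (0.10 log units; within the scatter) is expected to stay within the scatter.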

Compound 3, half-maximal inhibitory concentration: 360 nM
The estimate for compound 3 lay 6.9-fold (0.84 log units) above the measured number, outside the stated range (below it).
By their numbers in this assay, from the lowest: compound 3; then compound 2; then compound 1.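

In this assay, the methoxy on the core of compound 1 proves dispensable for inhibition: hydrogen in its place gives a 5.5-fold lower number from compound 1 to compound 3 (0.74 log units; beyond the scatter). Among the compounds shown here, this is the first single-place change, and it shows that this aromatic carbon responds to substitution, with the unsubstituted form favoured over methoxy. No measurement at hand accounts for the step.

Still open, as far as these compounds go, is whether any group at this position matches hydrogen, for example fluorine, a hydroxyl, an amine or a longer alkoxy chain.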